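A few compounds are considered here, and "the series" means these few. Any claim that something is new, unique, unknown or untested is made for them only; others in the source may bear on it.

Measured compounds:
compound 1 `O=C(Nc1ccccc1I)N[C@H]1CC[C@H](Oc2ccc(F)cc2)CC1` — > 20000 nM
compound 2 `COc1cccc(NC(=O)N[C@H]2CC[C@H](Oc3ccc(F)cc3)CC2)c1` — 14000 nM

In a functional assay on CRL2813 cells (Homo sapiens) for cytotoxicity, read by sulforhodamine B assay, with a stated time of 5 days (a higher number here means a weaker inhibitor, a lower number a stronger inhibitor), compound 1 returns only a limit, > 20000 nM. Among the compounds with values here, compound 2 is the single compound with an actual number in this set; in this assay compound 2 gives 14000 nM. Within the data shown here, the one measured step, an at least 1.4-fold lower number from compound 1 to compound 2 (0.15 log units; that floor lies within the scatter), rests on that limit (the limit of > 20000 nM in this assay, at which 1 of the 2 values shown sits), and its floor sits within the scatter, so it fixes no real size of effect for swapping the aryl group on the amide-type nitrogen.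

Compound 3 `CSc1ccc(NC(=O)N[C@H]2CC[C@H](Oc3ccc(F)cc3)CC2)cc1` differs from compound 2 in one place: 4-(methylsulfanyl)phenyl in place of 3-methoxyphenyl on an amide-type nitrogen. Among the measured compounds shown here, no measured step changes that group in the same way, so the measured material gives scale only: the series is weak throughout, and the one aryl swap seen so far moved the number by an amount whose floor lies within the scatter. The expected step of a 1.1-fold higher number from compound 2 to compound 3 (0.03 log units; within the scatter) is therefore small, in no set direction. Compound 3 is estimated at 15000 nM, with a range from 6000 nM to 40000 nM.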

Compound 3, half-maximal inhibitory concentration: > 20000 nM
Compound 3: no number, only a limit (the forecaster's own chance of this, stated with the estimate: 40%); at least 1.3-fold (0.12 log units) between middle value and limit.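

On the amide-type nitrogen, 4-(methylsulfanyl)phenyl in place of 3-methoxyphenyl gives an at least 1.4-fold higher number from compound 2 to compound 3 (0.15 log units; that floor lies within the scatter) in this assay, which fixes no real size of effect for this change. The value of compound 3 is a limit of the assay and not a number, and the step between compound 1 and compound 3 cannot be read. With a second aryl group now ending at that limit, compound 2 remains the only compound with an actual number, and the readings collect at one point: the limit of > 20000 nM in this assay, at which 2 of the 3 values shown sit.

Going by these compounds, whether any group on this nitrogen moves the number beyond the scatter remains open, including a carboxylic acid or a primary amine on the phenyl ring. The shared core is the same in all three compounds, so what a change there would do is also unknown.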